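A Trifluoroethyl Carbamate in Place of the Boc Group

The source may report more compounds than this note shows. Statements on the series, on what has been measured and on what is new or still open speak of the compounds shown alone.

Measured so far in an assay on MCF7 cells for inhibition of Serine-protein kinase ATM (Homo sapiens), read by immunofluorescence, with a stated time of 1 h; a lower number here means a stronger inhibitor, a higher number a weaker inhibitor:
compound 1 `COc1cc2ncnc(-n3nc(-c4ccccn4)nc3N)c2cc1OCc1ccccc1` gives 8600 nM
compound 2 `COc1cc2ncnc(-n3nc(-c4ccccn4)nc3N)c2cc1OCCCNC(=O)OC(C)(C)C` gives 900 nM
compound 3 `COc1cc2ncnc(-n3nc(-c4ccccn4)nc3N)c2cc1OCCCCNC(=O)OC(C)(C)C` gives 800 nM

Compound 3 shows the lowest number of the three, but its gap to compound 2 is within the scatter, a 1.1-fold lower number from compound 2 to compound 3 (0.05 log units; within the scatter), so only compound 1 is clearly separated from it, an 11-fold lower number from compound 1 to compound 3 (1.03 log units; beyond the scatter). Compound 4 `COc1cc2ncnc(-n3nc(-c4ccccn4)nc3N)c2cc1OCCCNC(=O)OCC(F)(F)F` differs from compound 3 by ((2,2,2-trifluoroethoxy)carbonyl)amino in place of ((tert-butoxycarbonyl)amino)methyl on a saturated chain carbon, three bonds along the chain from an oxygen on an aromatic ring. Two of the measured steps bear on this change. The step of a 9.6-fold lower number from compound 1 to compound 2 (0.98 log units; beyond the scatter) shows that bringing in a carbamate-bearing chain in place of the phenyl lowers the number markedly, and compound 4 retains a carbamate on a chain of the same kind. The step from compound 2 to compound 3 shows that lengthening that chain by one carbon does no more than the scatter allows, so the shorter chain in compound 4 is not expected to matter. Among the compounds with values here, no measured pair changes the alkoxy part of the carbamate, so the trifluoroethoxy group itself is untested. Compound 4 is therefore expected to lie close to compound 3, with a 1.1-fold higher number from compound 3 to compound 4 (0.05 log units; within the scatter) and an estimate of 900 nM, between 300 nM and 2700 nM.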

Compound 4, half-maximal inhibitory concentration: 1200 nM
Compound 4: middle estimate off by 1.3-fold (0.12 log units), on the low side, within the range that was stated.
By their numbers in this assay, from the lowest: compounds 3, 2 and 4 (each within the scatter of the next); then compound 1.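

In this assay, within the data shown here, the pair of compound 2 and compound 4 is the only one that changes the alkoxy part of the carbamate, and 2,2,2-trifluoroethyl in place of tert-butyl on an oxygen next to a carbonyl group stays within the scatter (a 1.3-fold higher number from compound 2 to compound 4 (0.12 log units; within the scatter)). The exchange of ((tert-butoxycarbonyl)amino)methyl for ((2,2,2-trifluoroethoxy)carbonyl)amino also stays within the scatter (a 1.5-fold higher number from compound 3 to compound 4 (0.18 log units; within the scatter)), while the trifluoroethyl carbamate chain remains clearly separated from the phenyl group (a 7.2-fold lower number from compound 1 to compound 4 (0.86 log units; beyond the scatter)). Nothing measured here explains this tolerance of the alkoxy change. The compounds shown leave open whether the carbamate itself is needed, as a free primary amine, an acetamide or a urea at the end of the chain would show. Also open, as far as these compounds go, is how a methyl carbamate or a longer chain would read here.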